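The source may report more compounds than this note shows. Statements on the series, on what has been measured and on what is new or still open speak of the compounds shown alone.

compound 1 `CC1(C)CC(NC(=S)Nc2ccc(C#N)cc2)c2cc(F)ccc2O1` gives 19000 nM
compound 2 `CC1(C)CC(NC(=S)Nc2cccc(C#N)c2)c2cc(F)ccc2O1` gives 39000 nM

Going by the values given here, in a functional assay on T98G cells (Homo sapiens) for inhibition, read by MTT assay, with a stated time of 72 h (on this read-out higher numbers stand for weaker inhibition and lower numbers for stronger inhibition), compound 1 stands at 19000 nM and holds the lower of the two numbers so far. Compound 3 `CC1(C)CC(NC(=S)Nc2ccc(C#N)cc2)c2cc(Cl)ccc2O1` has not yet been measured. It differs from compound 1 in one place: chloro in place of fluoro on an aromatic carbon. Among the compounds with values here, the only measured step is a 2.1-fold higher number from compound 1 to compound 2 (0.31 log units; beyond the scatter) and it is modest in size. That step lies elsewhere in the molecule, so it says nothing direct about this halogen swap. Within the data shown here, with that single modest step as the only guide, a small change is expected and the data give no firm direction. The expected step is a 1.1-fold lower number from compound 1 to compound 3 (0.05 log units; within the scatter) in this assay and this remains an estimate. For compound 3 the estimated value is 17000 nM with an expected range from 7000 nM to 40000 nM once it is measured.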

Compound 3, half-maximal inhibitory concentration: 10000 nM
Beside the measured number, compound 3's estimate is 1.7-fold (0.23 log units) above it; the measured number falls inside the stated range.
By their numbers in this assay, from the lowest: compounds 3 and 1 (each within the scatter of the next); then compound 2.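

Compounds 1 and 2 differ only in where the nitrile sits on the cyanophenyl ring, so they say nothing about the halogen-bearing aromatic carbon of the shared core. Here, chloro in place of fluoro gives a 1.9-fold lower number from compound 1 to compound 3 (0.28 log units; within the scatter) in this assay, so this assay does not separate the two halogens at this position, and either one is compatible with a value in the same range. Nothing available bears on the reason for this result.

Fluoro and chloro are the only groups shown on this carbon, so it remains open what a bromo group, a methoxy group or a plain hydrogen would give there. On these data alone, it also remains open whether the same holds for a urea, with oxygen in place of the thiourea sulfur.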